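The source may hold more compounds than are shown below. What is called first, only, known or untested is meant among the compounds shown, and "the series" means these compounds.

Compound 2 `O=C(NCc1ccc(CNS(=O)(=O)c2ccccc2)cc1)c1c(Cl)cc(Cl)cc1Cl` and compound 3 `Cc1ccc(S(=O)(=O)NCc2ccc(CNC(=O)c3c(Cl)cc(Cl)cc3Cl)cc2)cc1` share most of their structure. In an assay on MDA-MB-231 cells for binding affinity to C-X-C chemokine receptor type 4 (Homo sapiens), read by immunofluorescence and microscopy, with stated times of 10 min and 30 min (on this read-out higher numbers stand for an effect only at larger amounts of compound and lower numbers for an effect already at smaller amounts), compound 2 gives 10 nM, and compound 3 gives 10 nM. The two cores differ by methyl in place of hydrogen on an aromatic carbon, a change that made no change at the digits printed from compound 2 to compound 3 (within the scatter). Compound 1 `O=C(NCc1ccc(CNS(=O)(=O)c2ccccc2)cc1)c1cccc(F)c1` carries the change (3-fluorophenyl in place of 2,4,6-trichlorophenyl on a carbonyl carbon); in this assay compound 1 gives 100 nM, so that change made a 10-fold higher number from compound 2 to compound 1 (1.00 log units; beyond the scatter). Compound 4 `Cc1ccc(S(=O)(=O)NCc2ccc(CNC(=O)c3cccc(F)c3)cc2)cc1` has not yet been measured. It differs from compound 3 by 3-fluorophenyl in place of 2,4,6-trichlorophenyl on a carbonyl carbon, the same change that was made from compound 2 to compound 1, at a place described in identical words. For compound 4 a step of a 10-fold higher number from compound 3 to compound 4 (1.00 log units; beyond the scatter) is expected, resting on a 10-fold higher number from compound 2 to compound 1 (1.00 log units; beyond the scatter). Compound 4 is therefore estimated at 100 nM in this assay, with a likely range from 40 nM to 250 nM.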

Compound 4, effective concentration (reported as EC, without a stated level of effect): 1 nM
The estimate for compound 4 lay 100-fold (2.00 log units) above the measured number; measured number below the stated range.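

In this assay, 3-fluorophenyl in place of 2,4,6-trichlorophenyl on a carbonyl carbon does not carry over between the two cores, giving a 10-fold lower number from compound 3 to compound 4 (1.00 log units; beyond the scatter), opposite in direction to the earlier step: the same change on two cores in this assay, a 10-fold higher number (1.00 log units; beyond the scatter) from compound 2 to compound 1 and a 10-fold lower number (1.00 log units; beyond the scatter) from compound 3 to compound 4, 100-fold (2.00 log units) apart, beyond the scatter of two such steps

Methyl in place of hydrogen on an aromatic carbon also depends on its partner group, giving a 100-fold lower number from compound 1 to compound 4 (2.00 log units; beyond the scatter): the same change on two cores in this assay, no change at the digits printed (within the scatter) from compound 2 to compound 3 and a 100-fold lower number (2.00 log units; beyond the scatter) from compound 1 to compound 4, 100-fold (2.00 log units) apart, beyond the scatter of two such steps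

The two changes therefore do not act independently across these four compounds, although this single set of four does not show why, or how either change would behave on any other core.

The compounds shown leave open whether a methoxy group or an amine in place of the methyl would follow the pattern of compound 4. They also leave open whether a single chlorine in place of the fluorine would do so.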